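A few compounds are considered here, and "the series" means these few. Any claim that something is new, unique, unknown or untested is made for them only; others in the source may bear on it.

In a functional assay on PC-3 cells (Homo sapiens) for inhibition, read by sulforhodamine B assay, with a stated time of 72 h (a higher number here means a weaker inhibitor, a lower number a stronger inhibitor), compound 1 `CC1CN(C(=O)c2c(N)sc(-c3ccc(Cl)cc3)c2-c2ccc(Cl)cc2)CCN1` gives 7210 nM and compound 2 `Nc1sc(-c2ccc(Cl)cc2)c(-c2ccc(Cl)cc2)c1C(=O)N1CCC(=O)CC1=O` gives 9230 nM, so compound 2 stands level with compound 1 within the scatter. Compound 3 `Nc1sc(-c2ccc(Cl)cc2)c(-c2ccc(Cl)cc2)c1C(=O)NC1CCCC1` has cyclopentylamino in place of 2,4-dioxopiperidin-1-yl on a carbonyl carbon. Within the data shown here, the only measured step, a 1.3-fold higher number from compound 1 to compound 2 (0.11 log units; within the scatter), changed the group at this same place and stayed within the scatter, so no step beyond the scatter is expected in this assay. The estimated step is a 1.2-fold lower number from compound 2 to compound 3 (0.09 log units; within the scatter). For compound 3 the expected value is 7500 nM, with an estimated range of 2500 nM to 20000 nM.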

Compound 3, half-maximal inhibitory concentration: 21200 nM
Estimate against measurement, compound 3: 2.8-fold (0.45 log units) below, outside the stated range (above it).
By their numbers in this assay, from the lowest: compounds 1 and 2 (each within the scatter of the next); then compound 3.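

In this assay the group on the carbonyl carbon now matters beyond the scatter: cyclopentylamino brings a 2.3-fold higher number from compound 2 to compound 3 (0.36 log units; beyond the scatter) and also a 2.9-fold higher number from compound 1 to compound 3 (0.47 log units; beyond the scatter), whereas 2,4-dioxopiperidin-1-yl and 3-methylpiperazin-1-yl stood level. This position therefore does not treat all groups alike. No measurement shown accounts for this change.

The compounds shown do not separate the amide hydrogen of cyclopentylamino from its carbon-only ring. As far as these compounds go, how morpholin-4-yl or an open-chain amine such as diethylamino would read at this position remains open.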